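Extending the acrylamide end of compound 2 with a diethylamino chain

A few compounds are considered here, and "the series" means these few. Any claim that something is new, unique, unknown or untested is made for them only; others in the source may bear on it.

Of the compounds shown here, three sharing one core have been measured in a functional assay on MCF7 cells (Homo sapiens) for antiproliferative activity, read by MTT assay, with a stated time of 72 h; on this read-out higher numbers stand for weaker inhibition and lower numbers for stronger inhibition. Compound 1 `C=CC(=O)Nc1cc2c(N3CCc4ccccc43)ncnc2cc1OC` gives 11700 nM. Compound 2 `C=CC(=O)Nc1cc2c(N3CCc4ccccc43)ncnc2cc1O[C@@H]1CCOC1`, which carries an oxolan-3-yl in place of methyl on an oxygen on an aromatic ring, gives 5950 nM; the step of a 2.0-fold lower number from compound 1 to compound 2 (0.29 log units; within the scatter) is small. Compound 3 `CC(C)=CC(=O)Nc1cc2c(N3CCCc4ccccc43)ncnc2cc1O[C@@H]1CCOC1` gives 11100 nM. Compound 2 stands among these numbers without separation from either neighbour beyond the scatter, so no one of the three can be called the strongest.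

The untested compound 4 `CCN(CC)C/C=C/C(=O)Nc1cc2c(N3CCc4ccccc43)ncnc2cc1O[C@@H]1CCOC1` keeps the core and the oxolan-3-yl of compound 2 and differs only at the acrylamide: 3-(diethylamino)prop-1-en-1-yl in place of vinyl on a carbonyl carbon. For the measured compounds named here, no measured step touches this carbonyl carbon, and compound 3 changes two places at once against compound 2, so its value alone cannot be read as a step. Going by the values given here, the only measured step, a 2.0-fold lower number from compound 1 to compound 2 (0.29 log units; within the scatter), sits elsewhere and was within the scatter. The step of a 1.5-fold lower number from compound 2 to compound 4 (0.17 log units; within the scatter) is therefore expected to stay small. Compound 4 is estimated at 4000 nM, between 1500 nM and 12000 nM.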

Compound 4, half-maximal inhibitory concentration: 4980 nM
Compound 4: the middle estimate sits 1.2-fold (0.10 log units) below what was measured; the range from low to high includes it.
By their numbers in this assay, from the lowest: compounds 4, 2, 3 and 1 (each within the scatter of the next, the first and the last beyond it).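

For the compounds shown here, this is the first measured change at the carbonyl carbon, and in this assay it gives a 1.2-fold lower number from compound 2 to compound 4 (0.08 log units; within the scatter). Replacing vinyl with the much larger 3-(diethylamino)prop-1-en-1-yl, which brings in a nitrogen and a hydrogen-bond acceptor, therefore leaves compound 4 indistinguishable from compound 2 on this read-out, so this carbonyl carbon can carry the longer chain with no measurable change in the antiproliferative number. Nothing available bears on why the number holds steady across so large a change.

As far as these compounds go, whether the same holds for a dimethylamino group, a morpholine ring or a longer carbon chain carrying the amine stays open. Also open, from the compounds shown here alone, is whether any group on this carbonyl carbon can move the number beyond the scatter.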